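The compounds below may be only part of what the source reports. "The series", "measured", "known", "first", "only" and "open" are said of these compounds alone.

Measured in an ADME assay on MT2 cells (Homo sapiens) for cytotoxicity, read by MTT assay; on this read-out higher numbers stand for lower toxicity in this test and lower numbers for higher toxicity in this test:
compound 1 `COCCOc1nc(Nc2ccc(C#N)c(OCC=C(C)C)c2)nc(OC)n1` gives 8600 nM
compound 2 `COCCOCCOc1nc(Nc2ccc(C#N)c(OCC=C(C)C)c2)nc(OC)n1` gives 13000 nM
compound 3 `COCCOCCOCCOc1nc(Nc2ccc(C#N)c(OCC=C(C)C)c2)nc(OC)n1` gives 4200 nM

Compound 1 stands second highest of the three numbers in this assay. Its nearest neighbour is compound 2, reached by a 1.5-fold higher number from compound 1 to compound 2 (0.18 log units; within the scatter), a step that stays within the scatter. Its furthest is compound 3, reached by a 2.0-fold lower number from compound 1 to compound 3 (0.31 log units; beyond the scatter), a modest step beyond the scatter. Between the other two, a 3.1-fold lower number from compound 2 to compound 3 (0.49 log units; beyond the scatter) is also modest and beyond the scatter. All three measured steps change only the length of the chain on the oxygen at one position of the shared core.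

The unmeasured compound 4 `CCc1nc(Nc2ccc(C#N)c(OCC=C(C)C)c2)nc(OCCOC)n1` differs from compound 1 in another place: ethyl in place of methoxy on an aromatic carbon. Within the data shown here, no measured step touches this part of the shared core, so none of the three bears directly on the change. What the measured compounds do show is that the whole series sits within a narrow band in this assay, and a small change of two heavy atoms at a different position gives no ground to expect a departure from that band. The expectation is therefore a step of a 1.1-fold lower number from compound 1 to compound 4 (0.03 log units; within the scatter) from compound 1, with no change beyond the scatter and no direction preferred. Compound 4 is estimated at 8000 nM, with a range from 3500 nM to 18000 nM.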

Compound 4, half-maximal cytotoxic concentration: 2100 nM
The estimate for compound 4 lay 3.8-fold (0.58 log units) above the measured number; measured number outside the range, below it.
By their numbers in this assay, from the lowest: compounds 4 and 3 (each within the scatter of the next); then compounds 1 and 2 (each within the scatter of the next).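

In this assay the aromatic carbon between two ring nitrogen atoms proves to be a place where the number can move: ethyl in place of methoxy gives a 4.1-fold lower number from compound 1 to compound 4 (0.61 log units; beyond the scatter) and so a shift towards higher toxicity in this test. The earlier steps shown here changed only the chain on the oxygen, the largest being a 3.1-fold lower number from compound 2 to compound 3 (0.49 log units; beyond the scatter) and this exchange of two heavy atoms for two heavy atoms, which removes one hydrogen-bond acceptor from the position, is also a modest step beyond the scatter, so the chain is not the only part of the series tied to this read-out. No measurement on hand accounts for the step.

As far as these compounds go, with a single exchange at this position, it remains open whether the step goes with the loss of the methoxy oxygen or with the ethyl itself, and a methyl, a propyl or an amine on the same carbon would help to separate the two. From the compounds shown here alone, it also remains open whether ethyl in place of methoxy gives a similar step when the 2-methoxyethoxy group is replaced by the longer chains of compound 2 and compound 3.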